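The source may report more compounds than this note shows. Statements on the series, on what has been measured and on what is new or still open speak of the compounds shown alone.

Compound 1 `C[C@H](CSc1nonc1/C(=N/O)Nc1ccc(F)c(Br)c1)NC(=O)CS(N)(=O)=O`: 0.77 h
Compound 2 `NS(=O)(=O)CC(=O)NCCSc1nonc1/C(=N/O)Nc1ccc(F)c(Br)c1`: 2.37 h

In an ADME assay on microsomes from liver (Homo sapiens) for metabolic stability (a lower number here means that the compound disappears faster, a higher number that the compound lasts longer), compound 2 stands highest of the two, at 2.37 h. Compound 3 `C[C@@H](CSc1nonc1/C(=N/O)Nc1ccc(F)c(Br)c1)NC(=O)CS(N)(=O)=O` differs from it by methyl in place of hydrogen on a saturated chain carbon bound to an amide-type nitrogen and a saturated chain carbon. Among the compounds with values here, one measured step bears on this, the modest 3.1-fold higher number from compound 1 to compound 2 (0.49 log units; beyond the scatter), which removes a methyl of the opposite handedness at that place. The data do not show whether handedness matters, so a similar but less certain fall is expected. The expected step is a 2.2-fold lower number from compound 2 to compound 3 (0.33 log units; beyond the scatter). For compound 3 the estimate is 1.1 h, within 0.55 h to 2.4 h.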

Compound 3, half-life: 1.57 h
The estimate for compound 3 lay 1.4-fold (0.15 log units) below the measured number, and the stated range covers the measured number.
By their numbers in this assay, from the lowest: compound 1; then compounds 3 and 2 (each within the scatter of the next).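

Methyl in place of hydrogen at this position now has a measured result for each handedness. With the methyl drawn S, the change is a 1.5-fold lower number from compound 2 to compound 3 (0.18 log units; within the scatter) in this assay and stays within the scatter. The two handednesses are themselves apart, with a 2.0-fold higher number from compound 1 to compound 3 (0.31 log units; beyond the scatter) beyond the scatter, and this gap arises with the same atoms and bonds: the fact that compounds 1 and 3 differ only in the configuration as drawn. On these data alone, whether an ethyl group or a longer chain on this carbon would show the same gap between handednesses remains open. So does the result of placing an amine or a carboxylic acid there.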